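The source may hold more compounds than are shown below. What is called first, only, known or untested is meant among the compounds shown, and "the series" means these compounds.

Measured in a functional assay on MCF7 cells (Homo sapiens) for inhibition; on this read-out lower numbers stand for stronger inhibition of growth and higher numbers for weaker inhibition of growth:
- Compound 1 `O=C(OCc1ccccc1)c1ccsc1NC(=O)[C@@H]1CCCN1`: > 250 ug/mL, a limit of the assay and not a number
- Compound 2 `O=C(OC1CCCCC1)c1ccsc1NC(=O)[C@@H]1CCCN1`: 162 ug/mL
- Compound 3 `C=CCOC(=O)c1ccsc1NC(=O)[C@@H]1CCCN1`: 96.6 ug/mL

Compound 3 gives 96.6 ug/mL, and the comparison between the two actual numbers is a 1.7-fold lower number from compound 2 to compound 3 (0.22 log units; within the scatter). Against the limit, the comparison is an at least 2.5-fold lower number from compound 1 to compound 3 (0.41 log units; beyond the scatter).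

Compound 4 `O=C(OCC(F)(F)F)c1ccsc1NC(=O)[C@@H]1CCCN1` has trifluoromethyl in place of vinyl on a saturated chain carbon bound to an oxygen next to a carbonyl group. Among the compounds with values here, no measured step makes this exchange, so the evidence is indirect. Two steps change the same place and bear on it: a 1.7-fold lower number from compound 2 to compound 3 (0.22 log units; within the scatter) and an at least 2.5-fold lower number from compound 1 to compound 3 (0.41 log units; beyond the scatter). The second shows that a change here can exceed the scatter, but it replaces phenyl, a larger group than the trifluoromethyl entering here.

In this assay, the expected step is a 1.2-fold higher number from compound 3 to compound 4 (0.09 log units; within the scatter), so no shift beyond the scatter is anticipated. For compound 4, the estimated value is 120 ug/mL, with an expected range from 55 ug/mL to 250 ug/mL.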

Compound 4, concentration for 50% growth inhibition: 89.7 ug/mL
The estimate for compound 4 lay 1.3-fold (0.13 log units) above the measured number, within the range that was stated.
By their numbers in this assay, from the lowest: compounds 4, 3 and 2 (each within the scatter of the next). At a limit, above all of these: compound 1.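

In this assay, trifluoromethyl in place of vinyl on a saturated chain carbon bound to an oxygen next to a carbonyl group gives a 1.1-fold lower number from compound 3 to compound 4 (0.03 log units; within the scatter), so allyl and 2,2,2-trifluoroethyl cannot be told apart on this read-out. The exchange of cyclohexyl for 2,2,2-trifluoroethyl, a 1.8-fold lower number from compound 2 to compound 4 (0.26 log units; within the scatter), does not separate those two groups either, which leaves compounds 2, 3 and 4 within the scatter of one another. Only an at least 2.7-fold lower number from compound 1 to compound 4 (0.44 log units; beyond the scatter) goes beyond the scatter, and its size is a floor, since compound 1 stands at a limit of the assay and not a number: the limit of > 250 ug/mL in this assay, at which 1 of the 4 values shown sits.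

The compounds shown leave open whether an amine, a carboxylic acid or a longer chain in this place would move the number beyond the scatter. From the compounds shown here alone, how far compound 1 truly lies from the other three also stays open.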